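Fluorine on the Triazole Phenyl of a Sulfonamide Series

The compounds below may be only part of what the source reports. "The series", "measured", "known", "first", "only" and "open" are said of these compounds alone.

Two measured members of this series are compound 1 `Cc1ccc(-n2cc(-c3cccc(NS(=O)(=O)c4c[nH]c(=O)[nH]c4=O)c3)nn2)cc1` and compound 2 `O=c1[nH]cc(S(=O)(=O)Nc2ccc(-c3cn(-c4ccccc4)nn3)cc2)c(=O)[nH]1`. In a functional assay on SGC-7901 cells (Homo sapiens) for antiproliferative activity, read by MTT assay, with a stated time of 24 h (a lower number here means a stronger inhibitor, a higher number a weaker inhibitor), compound 1 gives 9430 nM, and compound 2 gives 18800 nM; the two values lie within the scatter of each other, so no order between them can be read. Compound 3 `O=c1[nH]cc(S(=O)(=O)Nc2ccc(-c3cn(-c4ccc(F)cc4)nn3)cc2)c(=O)[nH]1` differs from compound 2 by fluoro in place of hydrogen on an aromatic carbon. Among the measured compounds shown here, no measured pair shows this change here, so the step from compound 2 to compound 3 is expected to stay within the scatter, with a 1.3-fold lower number from compound 2 to compound 3 (0.10 log units; within the scatter) as the estimate. Compound 3 is expected to give 15000 nM, between 6000 nM and 40000 nM.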

Compound 3, half-maximal inhibitory concentration: > 20000 nM
Compound 3 gave a limit, no number; the forecaster's own chance of this, stated with the estimate: 10%; at least 1.3-fold (0.12 log units) between middle value and limit.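

In this assay compound 3 gives > 20000 nM, which is a limit of the assay and not a number. Fluoro on the aromatic carbon para to a large group gives an at least 1.0-fold higher number from compound 2 to compound 3 (0.02 log units; that floor lies within the scatter), so this floor alone does not set the fluoro compound apart from its unsubstituted phenyl parent. What bears on the result is the assay limit itself: the limit of > 20000 nM in this assay, at which 1 of the 3 values shown sits.

On these data alone, the true size of the phenyl to 4-fluorophenyl step stays open. So does how an amine or a carboxylic acid at this same carbon would read.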